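The source may hold more compounds than are shown below. What is called first, only, known or untested is meant among the compounds shown, and "the series" means these compounds.

Going by the values given here, compound 1 `OC[C@H]1O[C@@H](n2cnc3c(Sc4ccccc4)ncnc32)[C@H](O)[C@@H]1O` is one of three compounds measured in an assay on isolated protein for binding affinity to Equilibrative nucleoside transporter 1 (Homo sapiens); on this read-out higher numbers stand for weaker inhibition and lower numbers for stronger inhibition. In this assay compound 1 gives 91200 nM, the second highest of the three numbers; compound 3 `Nc1nc(SCCc2ccccc2)c2ncn([C@@H]3O[C@H](CO)[C@@H](O)[C@H]3O)c2n1` gives 16200 nM and compound 2 `Cc1cccc(CSc2nc(N)nc3c2ncn3[C@@H]2O[C@H](CO)[C@@H](O)[C@H]2O)n1` gives 11500000 nM. Compound 4 `OC[C@H]1O[C@@H](n2cnc3c(CSc4ccc(I)cc4)ncnc32)[C@H](O)[C@@H]1O` differs from compound 1 by a group of 9 heavy atoms (7 carbon, 1 sulfur, 1 iodine; one six-membered aromatic ring of carbon only) in place of a group of 7 heavy atoms (6 carbon, 1 sulfur; one six-membered aromatic ring of carbon only), on an aromatic carbon. Among the compounds with values here, the one measured step in this region, a 710-fold lower number from compound 2 to compound 3 (2.85 log units; beyond the scatter), concerns the group on the chain carbon bound to sulfur and was large; it does not match the present change, so it gives only a loose guide. Compound 3, whose group on sulfur also extends beyond a single aromatic ring, sits lower than compound 1, so a moderately lower number is expected for compound 4, an estimated step of a 4.6-fold lower number from compound 1 to compound 4 (0.66 log units; beyond the scatter). The estimated value for compound 4 is 20000 nM, within 4000 nM to 100000 nM.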

Compound 4, half-maximal inhibitory concentration: 69.2 nM
Compound 4: the middle estimate sits 290-fold (2.46 log units) above what was measured; measured number outside the range, below it.
By their numbers in this assay, from the lowest: compound 4; then compound 3; then compound 1; then compound 2.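

In this assay, putting the group of 9 heavy atoms with iodine in place of phenylsulfanyl on this aromatic carbon gives a 1300-fold lower number from compound 1 to compound 4 (3.12 log units; beyond the scatter). Going by these compounds alone, none of the earlier compounds showed a change at this position, and here the step is large even though both groups hold one six-membered aromatic ring of carbon only and the same hydrogen-bond donor and acceptor counts. Nothing available accounts for the size of this step.

Compound 4 gains iodine and an extra carbon together, so the compounds shown do not separate the two. From the compounds shown here alone, how a bromine or a methoxy group in place of the iodine would read remains open.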